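Amide in place of acid on a shared core

The source may report more compounds than this note shows. Statements on the series, on what has been measured and on what is new or still open speak of the compounds shown alone.

Compound 1 `CCOC(=O)c1sc2nc(-c3cccs3)cc(C(F)(F)F)c2c1N` — > 20000 nM
Compound 2 `Nc1c(C(=O)O)sc2nc(-c3ccccc3)cc(C(F)(F)F)c12` — > 20000 nM

Of the compounds shown here, two have been measured in an ADME assay on Huh-7 cells (Homo sapiens) for cytotoxicity, read by MTT assay, with a stated time of 72 h; a lower number here means that less compound is tolerated, a higher number that more compound is tolerated. Compound 1 `CCOC(=O)c1sc2nc(-c3cccs3)cc(C(F)(F)F)c2c1N` gives only a limit in this assay, > 20000 nM. Compound 2 `Nc1c(C(=O)O)sc2nc(-c3ccccc3)cc(C(F)(F)F)c12` likewise gives only a limit, > 20000 nM. Both values therefore sit at the limit of > 20000 nM in this assay, at which 2 of the 2 values shown sit, and no number separates them.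

Compound 3 `Nc1c(C(=O)NCc2cccs2)sc2nc(-c3ccccc3)cc(C(F)(F)F)c12` has not yet been measured in this assay. It differs from compound 2 by ((thiophen-2-yl)methyl)amino in place of hydroxy on a carbonyl carbon. Going by the values given here, since no measured pair shows this change, there is no measured step to lean on. Compound 3 is expected to stay close to the limit, with a step from compound 2 that is expected to be a step that the limit leaves unreadable from compound 2 to compound 3, within the scatter or not reported at all. The estimate for compound 3 is 25000 nM, spanning 8000 nM to 60000 nM.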

Compound 3, half-maximal cytotoxic concentration: > 20000 nM
Compound 3: only a limit was reported (the forecaster's own chance of this, stated with the estimate: 70%); the middle value is on the limit's open side.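

In this assay compound 3 gives only a limit, > 20000 nM. Compound 2 also gives only a limit, so no step can be read between compound 2 and compound 3: the limit of > 20000 nM in this assay, at which 3 of the 3 values shown sit.

The compounds shown leave open at what concentration any of the three becomes cytotoxic, and whether ((thiophen-2-yl)methyl)carbamoyl in place of carboxy changes that concentration at all.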